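Isopropylamino in place of phenyl on the shared core

The compounds below may be only part of what the source reports. "The series", "measured", "known", "first", "only" and "open" are said of these compounds alone.

Measured so far in an assay on isolated protein for inhibition of tyrosine-protein kinase receptor UFO (Homo sapiens), with a stated time of 1.5 h; on this read-out lower numbers stand for stronger inhibition and higher numbers for weaker inhibition:
- compound 1, `Cn1cc(-c2n[nH]c3cc(-c4ccccc4)ccc23)cn1`: 12300 nM
- compound 2, `Nc1cccc2[nH]nc(Br)c12`: 486000 nM
- compound 3, `O=C(O)c1ccc2c(Br)n[nH]c2c1`: a limit, > 770000 nM

Compound 1 holds the lowest of the two numbers shown in this assay; compound 2 sits a gap beyond the scatter higher. For compound 3 only a limit is known, > 770000 nM, not a number. It is the limit of > 770000 nM in this assay, at which 1 of the 3 values shown sits.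

Compound 4 is `CC(C)Nc1ccc2c(-c3cnn(C)c3)n[nH]c2c1`. Against compound 1 the change is isopropylamino in place of phenyl on an aromatic carbon. Compound 4 keeps the rest of compound 1 unchanged. Within the data shown here, no measured pair shows this change, so the size of the step is not anchored by data; compounds 2 and 3 differ from compound 1 in other places and carry no comparable group. The expectation is a step of modest size, within or near the scatter, with the direction uncertain. The estimated value for compound 4 in this assay is 8000 nM, within 1500 nM to 40000 nM, which is expected to mean a step of a 1.5-fold lower number from compound 1 to compound 4 (0.19 log units; within the scatter).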

Compound 4, half-maximal inhibitory concentration: 46600 nM
Estimate against measurement, compound 4: 5.8-fold (0.77 log units) below; measured number above the stated range.
By their numbers in this assay, from the lowest: compound 1; then compound 4; then compound 2. At a limit, above all of these: compound 3.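

Among these compounds, at this aromatic carbon, isopropylamino in place of phenyl gives a 3.8-fold higher number from compound 1 to compound 4 (0.58 log units; beyond the scatter) in this assay, the first step that can be read between two compounds differing in one place. The six-membered aromatic ring is therefore not needed for a measured number at this position, although the phenyl of compound 1 gives the lower number of the pair, and the size of the step is modest. Nothing measured here bears on what lies behind this step.

With a single change at this position, the effect of losing the ring cannot be separated from the effect of adding the amino nitrogen. On these data alone, how a cyclohexyl ring or a phenylamino group on the same carbon would read remains open, as does whether a longer chain on that nitrogen would move the number in either direction.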